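The source may report more compounds than this note shows. Statements on the series, on what has been measured and on what is new or still open speak of the compounds shown alone.

Three compounds have been measured in a functional assay on HEK293 cells for agonist activity at Glucose-dependent insulinotropic receptor (Homo sapiens), read by cAMP accumulation, with a stated time of 30 min; a lower number here means a smaller maximal response, a higher number a larger maximal response:

Compound 1 `CC1(OC(=O)N2C[C@H]3COC[C@@H](C2)[C@@H]3Oc2ncnc(Nc3ccc(C#N)cc3Cl)c2F)CC1` gives 92%
Compound 2 `CC1(COC(=O)N2CC3COCC(C2)C3Oc2ncnc(Nc3ccc(C#N)cc3Cl)c2F)COC1` gives 41%
Compound 3 `CC1(OC(=O)N2CC3COCC(C2)C3Oc2ncnc(Nc3ccc(C#N)cc3Cl)c2F)CCC1` gives 59%

Compound 3 stands second of the three in this assay: its value lies beyond the scatter above that of compound 2 and beyond the scatter below that of compound 1. Among the measured compounds shown here, the only step between two measured compounds that differ in one place is a number 18 percentage points higher from compound 2 to compound 3 (beyond the scatter), where 1-methylcyclobutyl replaced (3-methyloxetan-3-yl)methyl on an oxygen next to a carbonyl group.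

Compound 4 `N#Cc1ccc(Nc2ncnc(OC3C4COCC3CN(C(=O)OC3CCC3)C4)c2F)c(Cl)c1` differs from compound 3 by hydrogen in place of methyl on a saturated ring carbon; cut one bond further out, the change reads 1-methylcyclobutyl to cyclobutyl. For the measured compounds named here, no measured step removes a methyl from a saturated ring carbon, so the data give no direct guide. Going by the values given here, the one measured step swapped the whole group on that oxygen and moved the value by a modest amount, which suggests that this part of the structure matters, but a smaller trim is expected to move the value less. Compound 4 is therefore expected to sit close to compound 3, with a step of a number 7 percentage points lower from compound 3 to compound 4 (within the scatter) that may fall within the scatter, and its estimated value is 52%, in the range 35% to 70%.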

Compound 4, largest response reached (reported as percent of maximum), in percent of the reference or control that the assay uses: 51%
For compound 4 the middle estimate is 1 percentage points above the measured one; the range from low to high includes it.
By their numbers in this assay, from the lowest: compounds 2, 4 and 3 (each within the scatter of the next, the first and the last beyond it); then compound 1.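

In this assay, taking the methyl off this saturated ring carbon gives a number 8 percentage points lower from compound 3 to compound 4 (within the scatter), so the trim from 1-methylcyclobutyl to cyclobutyl leaves no difference that can be told from the scatter. Placing cyclobutyl where compound 2 carries (3-methyloxetan-3-yl)methyl gives a number 10 percentage points higher from compound 2 to compound 4 (within the scatter), which also lies within the scatter, even though a number 18 percentage points higher from compound 2 to compound 3 (beyond the scatter) is beyond it; compound 4 therefore cannot be separated from either of the other two, while those two can be separated from each other. No supporting evidence is available to explain any of these numbers.

Still open, going by these compounds, is how a quite different group on this oxygen, such as a straight butyl chain or a chain ending in an amine, would read in this assay. Also open, on these data alone, is whether removing a methyl would likewise stay within the scatter in the setting of compound 1 , which gives 92% and carries a 1-methylcyclopropyl group on that oxygen.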